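Methylsulfanyl for methylsulfonyl on the aromatic carbon

This account rests on a few compounds, and the source may have more. Where it says the series, first, only, none or still open, it means among the compounds named here.

Compound 1 `CC1(C)OC(/C=C/c2ccc(S(C)(=O)=O)cc2)=CC1=O` stands highest of the two numbers in hand: in a functional assay on the whole organism for inhibition, with Rattus norvegicus as the target, with a stated time of 1 h, at a dose of 25 mg/kg by the oral route (on this read-out higher numbers stand for more inhibition at the one dose given (going by the name of the read-out) and lower numbers for less inhibition), compound 1 gives 56%, while compound 2 `CC1(C)OC(c2ccc(Br)cc2)=CC1=O` gives 36%, a gap beyond the scatter. Among the compounds with values here, no step between measured compounds bears on the change to compound 3 `CSc1ccc(/C=C/C2=CC(=O)C(C)(C)O2)cc1`, which carries methylsulfanyl in place of methylsulfonyl on an aromatic carbon. Within the data shown here, with no measured precedent for this change, a modest loss relative to compound 1 is expected, without confidence in the direction. The expected step is a number 11 percentage points lower from compound 1 to compound 3 (beyond the scatter). For compound 3 the estimated value is 45%, with a range from 20% to 68%.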

Compound 3, a percentage reported as inhibition, in the whole organism at one dose (the size of the read-out at that dose, not a potency): 5%
Estimate against measurement, compound 3: 40 percentage points above; measured number outside the range, below it.
By their numbers in this assay, from the lowest: compound 3; then compound 2; then compound 1.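

Methylsulfanyl in place of methylsulfonyl on this aromatic carbon, para to a large group, gives a number 51 percentage points lower from compound 1 to compound 3 (beyond the scatter) in this assay and so shows that the level of the series depends strongly on the group at this place. Compound 2 could not show this, as it differs from compound 1 in more than one place. Nothing in hand gives a reason for the loss.

Open, going by these compounds, is whether a sulfonamide, a methylsulfinyl or a nitrile at this place would stay near compound 1 or fall toward compound 3.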